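Ester variation on a shared dihydropyridine core

The compounds below may be only part of what the source reports. "The series", "measured", "known", "first", "only" and "open" are said of these compounds alone.

Measured compounds:
compound 1 `CC1=C(C(=O)OC2CCCCC2)C(c2cccc(Br)c2)C2=C(CC(C)(C)CC2=O)N1`: 4150 nM
compound 2 `CC1=C(C(=O)OC2CCN(C(=O)OC(C)(C)C)CC2)C(c2cccc(Br)c2)C2=C(CC(C)(C)CC2=O)N1`: > 10000 nM
compound 3 `CC1=C(C(=O)OCc2cnccn2)C(c2cccc(Br)c2)C2=C(CC(C)(C)CC2=O)N1`: 860 nM

In an assay on HEK293 cells for inhibition of neurogenic locus notch homolog protein 1 (Homo sapiens), read by a luciferase reporter and resazurin assay, with a stated time of 16 h (a lower number here means a stronger inhibitor, a higher number a weaker inhibitor), compound 3 gives the lowest number of the two numbers reported; its nearest neighbour is compound 1, reached by a 4.8-fold lower number from compound 1 to compound 3 (0.68 log units; beyond the scatter). For compound 2 this assay reports only a limit, (the limit of > 10000 nM in this assay, at which 1 of the 3 values shown sits), and no number. Compound 4 `CC1=C(C(=O)O[C@H](CC#N)c2ccccc2)C(c2cccc(Br)c2)C2=C(CC(C)(C)CC2=O)N1` differs from compound 3 in one place: a group of 10 heavy atoms (9 carbon, 1 nitrogen; one six-membered aromatic ring of carbon only) in place of a group of 7 heavy atoms (5 carbon, 2 nitrogen; one six-membered aromatic ring with 2 hetero atoms), on an oxygen next to a carbonyl group. Among the measured compounds shown here, only the step from compound 1 to compound 3 bears on this position, and it was modest in size. The new group carries an aromatic ring but not the ring with 2 hetero atoms, so the step from compound 3 to compound 4 is expected to be a 1.9-fold higher number from compound 3 to compound 4 (0.27 log units; within the scatter), a somewhat higher number. Compound 4 is therefore estimated at 1600 nM, within a range of 400 nM to 6500 nM.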

Compound 4, half-maximal inhibitory concentration: > 10000 nM
Compound 4: a limit, no number (the forecaster's own chance of this, stated with the estimate: 15%); middle value at least 6.2-fold (0.79 log units) away from the limit.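

The aromatic ring alone does not carry the gain seen with compound 3 at this position: with a ring of carbon only in the group on the oxygen next to a carbonyl group, this assay shows an at least 11-fold higher number from compound 3 to compound 4 (1.06 log units; beyond the scatter). The new group also falls short of the cyclohexyl group, which has no aromatic ring, with an at least 2.4-fold higher number from compound 1 to compound 4 (0.38 log units; beyond the scatter). So the series does not simply reward an aromatic ring here, and compound 4, like compound 2, carries a limit and no number: the limit of > 10000 nM in this assay, at which 2 of the 4 values shown sit.

The ring, the nitrile-bearing chain and the defined stereocentre all change together in this step, so the compounds shown do not separate their contributions. Going by these compounds, whether a plain benzyl group or a pyridin-2-ylmethyl group on this oxygen would keep the level of compound 3 remains open.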